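Cyano-to-furanylmethylamino swap on the ring nitrogen aryl

This account rests on a few compounds, and the source may have more. Where it says the series, first, only, none or still open, it means among the compounds named here.

Compound 2 `COc1ccc([C@H]2CC(=O)N(c3cccc(C#N)c3)C2)cc1OC1CCCC1` is assessed in a functional assay on HEK293 cells (Homo sapiens) for cytotoxicity; on this read-out higher numbers stand for lower toxicity in this test and lower numbers for higher toxicity in this test. In this assay compound 2 gives only a limit, > 10000 nM. Compound 1 `COc1ccc([C@H]2CC(=O)N(c3ccccc3C#N)C2)cc1OC1CCCC1` likewise gives only a limit in this assay, > 10000 nM. Among the measured compounds shown here, the one measured step, a step that the two limits leave unreadable from compound 1 to compound 2, therefore has no readable size. For the measured compounds named here, both values sit at the limit of > 10000 nM in this assay, at which 2 of the 2 values shown sit, so nothing so far separates any two compounds.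

Compound 3 `COc1ccc([C@H]2CC(=O)N(c3cccc(NCc4ccoc4)c3)C2)cc1OC1CCCC1` differs from compound 2 by ((furan-3-yl)methyl)amino in place of cyano on an aromatic carbon. Going by the values given here, no measured step touches this change: the single step exchanges one cyanophenyl arrangement for another and is itself unreadable. In this assay, among the compounds with values here, then, no size of step can be read off; the only anchor is that compound 2 sits at the limit. Compound 3 is expected to remain near that limit, with a step that the limit leaves unreadable from compound 2 to compound 3 estimated to lie within scatter. The estimate for compound 3 in this assay is 15000 nM, range 4000 nM to 50000 nM.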

Compound 3, half-maximal cytotoxic concentration: > 10000 nM
Compound 3: a limit, no number; the forecaster's own chance of this, stated with the estimate: 75%; the middle value lies beyond the limit too.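

In this assay compound 3 gives > 10000 nM, a limit and not a number, so the step from compound 2 to compound 3 cannot be read: the limit of > 10000 nM in this assay, at which 3 of the 3 values shown sit.

From the compounds shown here alone, whether compound 1, compound 2 and compound 3 differ at all in this assay remains open.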